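Dropping one trifluoromethyl group: compound 1 to compound 3

The source may report more compounds than this note shows. Statements on the series, on what has been measured and on what is new or still open speak of the compounds shown alone.

Compound 1 `O=C(Nc1cccc(-n2cc(-c3ccncc3)c(-c3ccc(Cl)c(O)c3)n2)c1)Nc1cc(C(F)(F)F)cc(C(F)(F)F)c1` gives 1140 nM in a functional assay on Hs-578T cells (Homo sapiens) for inhibition, read by sulforhodamine B assay, with a stated time of 48 h (a higher number here means a weaker inhibitor of growth, a lower number a stronger inhibitor of growth), the lower of the two numbers recorded; compound 2 `COc1cc(-c2nn(-c3cccc(NC(=O)Nc4ccc(Cl)c(C(F)(F)F)c4)c3)cc2-c2ccncc2)ccc1Cl` gives 1320 nM in this assay, within the scatter of compound 1, so no order between them is claimed. Compound 3 `O=C(Nc1cccc(-n2cc(-c3ccncc3)c(-c3ccc(Cl)c(O)c3)n2)c1)Nc1cccc(C(F)(F)F)c1` is not yet measured. Its change from compound 1 is hydrogen in place of trifluoromethyl on an aromatic carbon. Within the data shown here, no step between measured compounds is recorded, so the size of this change is uncertain. The expected step is a 1.6-fold higher number from compound 1 to compound 3 (0.20 log units; within the scatter), no larger than the scatter or at most a modest rise. Compound 3 is therefore estimated at 1800 nM, with a range from 600 nM to 5500 nM.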

Compound 3, concentration for 50% growth inhibition: 3310 nM
Compound 3: the middle estimate sits 1.8-fold (0.26 log units) below what was measured, and the stated range covers the measured number.
By their numbers in this assay, from the lowest: compounds 1 and 2 (each within the scatter of the next); then compound 3.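

With the core of compound 1 held fixed, hydrogen in place of trifluoromethyl on this aromatic carbon gives a 2.9-fold higher number from compound 1 to compound 3 (0.46 log units; beyond the scatter) in this assay, a modest step. Among these compounds, this is the first step that exceeds the scatter, and it shows that this trifluoromethyl group contributes to growth inhibition, though only to a limited extent. The data available here offer no explanation for the size of this step.

As far as these compounds go, whether a chlorine, a nitrile or an amine on this carbon would stay closer to compound 1 or to compound 3 remains open. Also open, from the compounds shown here alone, is whether the same change has a similar effect on other cores.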